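A few compounds are considered here, and "the series" means these few. Any claim that something is new, unique, unknown or untested is made for them only; others in the source may bear on it.

In an assay on a protein complex for binding affinity to integrin alpha-5/beta-1 (Homo sapiens), read by ELISA (on this read-out lower numbers stand for stronger inhibition and higher numbers for weaker inhibition), compound 1 `N=C(N)NCCC[C@@H]1NC(=O)CNC(=O)C[C@@H](C(=O)O)NC(=O)[C@@H](c2ccccc2)NC(=O)CNC1=O` gives 19 nM, compound 2 `CC(C)[C@H]1NC(=O)[C@H](CCCNC(=N)N)NC(=O)CNC(=O)C[C@@H](C(=O)O)NC(=O)[C@@H](c2ccccc2)NC1=O` gives 7.3 nM and compound 3 `N=C(N)NCCC[C@@H]1NC(=O)CNC(=O)C[C@@H](C(=O)O)NC(=O)[C@@H](c2ccccc2)NC(=O)[C@@H](Cc2ccc(O)cc2)NC1=O` gives 8.7 nM; compound 3 thus stands second highest of these three numbers, nearest compound 2 and furthest from compound 1. Compound 4 `N=C(N)NCCC[C@@H]1NC(=O)CNC(=O)C[C@@H](C(=O)O)NC(=O)[C@@H](c2ccccc2)NC(=O)[C@@H](Cc2c[nH]c3ccccc23)NC1=O` differs from compound 3 by 1H-indol-3-yl in place of 4-hydroxyphenyl on a saturated chain carbon bound to a saturated ring carbon. Among the compounds with values here, the steps that bear on this are a 2.2-fold lower number from compound 1 to compound 3 (0.34 log units; beyond the scatter) and a 1.2-fold higher number from compound 2 to compound 3 (0.08 log units; within the scatter): a side group at the saturated ring carbon has given a modest lowering, and exchanging one side group for another has stayed within the scatter. Within the data shown here, no measured step covers the indole itself. The change from compound 3 to compound 4 in this assay is therefore expected to read a 1.1-fold lower number from compound 3 to compound 4 (0.04 log units; within the scatter). Compound 4 is accordingly estimated at 8 nM, with a range of 3 nM to 22 nM.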

Compound 4, half-maximal inhibitory concentration: 5.5 nM
Compound 4: middle estimate off by 1.5-fold (0.16 log units), on the high side; low and high end bracket the measured number.
By their numbers in this assay, from the lowest: compounds 4, 2 and 3 (each within the scatter of the next); then compound 1.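

In this assay the (1H-indol-3-yl)methyl group at the saturated ring carbon also reads lower than hydrogen, with a 3.5-fold lower number from compound 1 to compound 4 (0.54 log units; beyond the scatter) as a step beyond the scatter. The position therefore takes a group with a five-membered aromatic ring, yet a 1.6-fold lower number from compound 3 to compound 4 (0.20 log units; within the scatter) and a 1.3-fold lower number from compound 2 to compound 4 (0.12 log units; within the scatter) both stay within the scatter, so 4-hydroxybenzyl, isopropyl and (1H-indol-3-yl)methyl cannot be told apart here. No evidence at hand bears on these numbers.

On these data alone, how an amine, a carboxylic acid or a longer chain would read at this saturated ring carbon remains open.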